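The source may hold more compounds than are shown below. What is called first, only, known or untested is meant among the compounds shown, and "the series" means these compounds.

Compound 1 `CN1CCN(c2ccc(Nc3ncc4nc(Nc5ccc(F)cc5)n(-c5cccc(NC(=O)CO)c5)c4n3)cc2)CC1` gives 7.5 nM in a functional assay on HCC827 cells (Homo sapiens) for antiproliferative activity, read by MTT assay, with a stated time of 72 h (a lower number here means a stronger inhibitor, a higher number a weaker inhibitor), the highest number among the three measured compounds. Compound 2 `CN1CCN(c2ccc(Nc3ncc4nc(Nc5ccccc5)n([C@@H]5CCN(S(=O)(=O)C6CC6)C5)c4n3)cc2)CC1` gives 0.88 nM and compound 3 `CN1CCN(c2ccc(Nc3ncc4nc(Nc5ccccc5)n([C@H]5CCN(S(=O)(=O)C6CC6)C5)c4n3)cc2)CC1` gives 1.6 nM in this assay. For the measured compounds named here, the one measured single-point step, a 1.8-fold higher number from compound 2 to compound 3 (0.26 log units; within the scatter), rests on the fact that compounds 2 and 3 differ only in the configuration as drawn and stays within the scatter. Compound 4 `CNC(=O)CN1CC[C@H](n2c(Nc3ccc(F)cc3)nc3cnc(Nc4ccc(N5CCN(C)CC5)cc4)nc32)C1` differs from compound 1 by 1-((methylcarbamoyl)methyl)pyrrolidin-3-yl in place of 3-(((hydroxymethyl)carbonyl)amino)phenyl on an aromatic nitrogen. Going by the values given here, no measured step covers this exchange directly; compounds 2 and 3, which carry a pyrrolidinyl group on an aromatic nitrogen of the shared core, give lower numbers than compound 1, although the groups attached elsewhere in compound 4 differ from theirs. A lower number is therefore expected for compound 4, by a 3.8-fold lower number from compound 1 to compound 4 (0.57 log units; beyond the scatter). The estimate for compound 4 is 2 nM, between 0.7 nM and 6 nM.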

Compound 4, half-maximal inhibitory concentration: 1520 nM
Compound 4: middle estimate off by 760-fold (2.88 log units), on the low side, and the stated range ends below it.
By their numbers in this assay, from the lowest: compounds 2 and 3 (each within the scatter of the next); then compound 1; then compound 4.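

On an aromatic nitrogen of the shared core, the exchange of 3-(((hydroxymethyl)carbonyl)amino)phenyl for 1-((methylcarbamoyl)methyl)pyrrolidin-3-yl gives a 200-fold higher number from compound 1 to compound 4 (2.31 log units; beyond the scatter) in this assay. This position therefore responds strongly to the group it carries, and a five-membered non-aromatic ring there does not by itself secure a low number. Nothing at hand bears on the cause of this step.

Still open, on these data alone, is how this series would respond to an unsubstituted amine or a carboxylic acid in place of the (methylcarbamoyl)methyl chain on the pyrrolidine nitrogen. As far as these compounds go, the effect of the opposite configuration at the stereocentre of compound 4 also remains open.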